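The compounds below may be only part of what the source reports. "The series", "measured", "known", "first", "only" and "open" are said of these compounds alone.

Working notes on the acyl series. Compound 1 `C#CC(=O)N(Cc1ccc(OC)c(O)c1)c1cc(OC)c(OC)c(OC)c1` carries an ethynyl group on the carbonyl carbon; in a functional assay on MGC-803 cells (Homo sapiens) for inhibition, read by MTT assay, with a stated time of 48 h (on this read-out higher numbers stand for weaker inhibition and lower numbers for stronger inhibition), compound 1 gives 170 nM. Compound 2 `CCC(=O)N(Cc1ccc(OC)c(O)c1)c1cc(OC)c(OC)c(OC)c1` differs only at that carbonyl carbon, and in this assay compound 2 gives 50 nM. Going by the values given here, the single step between them, a 3.4-fold lower number from compound 1 to compound 2 (0.53 log units; beyond the scatter), is the only measured change so far. On the numbers shown, compound 2 holds the lowest of the two values, with compound 1 as its only neighbour.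

Compound 3 `COc1ccc(CN(C(=O)C(C)C)c2cc(OC)c(OC)c(OC)c2)cc1O` is next to be measured. Relative to compound 2 the change is methyl in place of hydrogen on a saturated chain carbon bound to a carbonyl carbon and a saturated chain carbon. Among the compounds with values here, no measured step carries this same change; the one step available, from compound 1 to compound 2, alters the group on the carbonyl carbon itself rather than adding a methyl further out, so it bears on compound 3 only loosely, as a sign that the acyl group can move the read-out by a modest amount. A step no larger than that is expected here, with no clear direction; the estimate for compound 3 is a 1.2-fold higher number from compound 2 to compound 3 (0.08 log units; within the scatter), giving 60 nM with a range from 25 nM to 150 nM.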

Compound 3, half-maximal inhibitory concentration: 210 nM
Estimate against measurement, compound 3: 3.5-fold (0.54 log units) below; the measured number lies above the stated range.
By their numbers in this assay, from the lowest: compound 2; then compounds 1 and 3 (each within the scatter of the next).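

In this assay, methyl in place of hydrogen on a saturated chain carbon bound to a carbonyl carbon and a saturated chain carbon, which turns ethyl into isopropyl, gives a 4.2-fold higher number from compound 2 to compound 3 (0.62 log units; beyond the scatter), so the read-out responds to a change this small at this place and not only to swapping the group on the carbonyl carbon. Exchanging the ethynyl group for isopropyl gives a 1.2-fold higher number from compound 1 to compound 3 (0.09 log units; within the scatter), which leaves these two groups within the scatter of each other, while the ethyl of compound 2 stands apart from both, with its steps to each printed as beyond the scatter. Nothing at hand accounts for the loss from ethyl to isopropyl.

On these data alone, it remains open whether a straight propyl chain or a cyclopropyl group on the carbonyl carbon would read close to compound 2 or close to compound 3, which would separate branching from simple chain length. As far as these compounds go, it is equally open whether a plain methyl on the carbonyl carbon would fall on the low side of compound 2 or whether ethyl marks the lowest point of this short set.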